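Replacing the Carbonyl Substituent of Compound 3 with an Arylamino Group

A few compounds are considered here, and "the series" means these few. Any claim that something is new, unique, unknown or untested is made for them only; others in the source may bear on it.

Of the compounds shown here, three have been measured in a functional assay on cells (Lymphocyte); a higher number here means a weaker inhibitor, a lower number a stronger inhibitor. Among the compounds with values here, compound 1 `O=C(COc1ccc(Cl)cc1)N1CCN(c2ncnc3sc(F)cc23)CC1` gives 6350 nM, compound 2 `CCCCc1nc(N2CCN(C(=O)COc3ccc(Cl)cc3)CC2)c2cc(F)sc2n1` gives 1330 nM, and compound 3 `Nc1nc(N2CCN(C(=O)COc3ccc(F)cc3)CC2)c2ccsc2n1` gives 66 nM, the lowest of the three numbers, with a 4.8-fold lower number from compound 1 to compound 2 (0.68 log units; beyond the scatter) the only measured step among them. Compound 4 `Nc1nc(N2CCN(C(=O)Nc3ccc(Cl)cc3)CC2)c2ccsc2n1` differs from compound 3 in one place: (4-chlorophenyl)amino in place of (4-fluorophenoxy)methyl on a carbonyl carbon. The measured step, a change of butyl for hydrogen on an aromatic carbon of the shared core, touches a different part of the molecule and offers no direct guide to a change at the carbonyl carbon; the values of compound 1 and compound 2 set beside compound 3 also combine two changes at once, so they show no single effect of the group on the carbonyl carbon. Without a measured precedent, a modest shift in either direction is expected in this assay, with the number for compound 4 more likely to stay near that of compound 3 than to move far. Compound 4 is therefore estimated at 150 nM, in the range 30 nM to 800 nM, meaning an expected step of a 2.3-fold higher number from compound 3 to compound 4 (0.36 log units; beyond the scatter).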

Compound 4, half-maximal inhibitory concentration: 6700 nM
The estimate for compound 4 lay 45-fold (1.65 log units) below the measured number, outside the stated range (above it).
By their numbers in this assay, from the lowest: compound 3; then compound 2; then compounds 1 and 4 (each within the scatter of the next).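

In this assay, within the data shown here, putting (4-chlorophenyl)amino in place of (4-fluorophenoxy)methyl on the carbonyl carbon gives a 100-fold higher number from compound 3 to compound 4 (2.01 log units; beyond the scatter) and so shows that this position, for which the earlier compounds offered no single-place step, is highly sensitive to change. Both groups hold one six-membered aromatic ring of carbon only, so keeping that ring does not preserve the number; the entering group also has a hydrogen-bond donor that the leaving group lacks. No measurement shown accounts for the size of this step.

The linking atoms and the halogen changed together, so the compounds shown leave open which of them goes with the step. A (4-fluorophenyl)amino group on the same carbonyl carbon would separate the two, and a (4-chlorophenyl)methylamino group would test the amide hydrogen.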